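A few compounds are considered here, and "the series" means these few. Any claim that something is new, unique, unknown or untested is made for them only; others in the source may bear on it.

In a functional assay on HL-60 cells (Homo sapiens) for antiproliferative activity, read by XTT assay, with a stated time of 72 h (a lower number here means a stronger inhibitor, a higher number a weaker inhibitor), compound 3 (`Cc1ncnc2c1c(-c1cccs1)cn2[C@@H]1O[C@H](CO)[C@@H](O)[C@H]1O`) gives 5730 nM as its measured value. Compound 1 (`COc1ncnc2c1c(-c1cc3ccccc3o1)cn2[C@@H]1O[C@H](CO)[C@@H](O)[C@H]1O`) gives 4470 nM as its value, so the two sit level, within the usual scatter. Compound 2 (`Cc1ncnc2c1c(-c1ccoc1)cn2[C@@H]1O[C@H](CO)[C@@H](O)[C@H]1O`) gives > 15000 nM as its reading, and this is a limit of the assay, not a number.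

The move to compound 4 (`Cc1ncnc2c1c(-c1cc3ccccc3o1)cn2[C@@H]1O[C@H](CO)[C@@H](O)[C@H]1O`) puts 1-benzofuran-2-yl in place of thiophen-2-yl on an aromatic carbon, as counted in 1-benzofuran-2-yl in place of thiophen-2-yl on an aromatic carbon, and so brings in one six-membered aromatic ring of carbon only. One measured step swaps groups at this same place: an at least 2.6-fold lower number from compound 2 to compound 3 (0.41 log units; beyond the scatter), which lies beyond the scatter, so a swap here can move the number. Yet compound 1 already carries 1-benzofuran-2-yl and shows 4470 nM as its value, level with compound 3. No shift beyond the scatter is therefore expected, and the estimated step is a 1.3-fold lower number from compound 3 to compound 4 (0.10 log units; within the scatter) in this assay for this swap. For compound 4 the estimated value is 4500 nM, with 1500 nM to 13000 nM as the expected range.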

Compound 4, half-maximal inhibitory concentration: > 20000 nM
Compound 4 gave a limit, no number; the forecaster's own chance of this, stated with the estimate: 12%; middle value at least 4.4-fold (0.64 log units) away from the limit.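

In this assay compound 4 stands at a limit of the assay, not at a number: the limit of > 20000 nM in this assay, at which 1 of the 4 values shown sits.

With methyl held constant, the change to 1-benzofuran-2-yl from thiophen-2-yl gives an at least 3.4-fold higher number from compound 3 to compound 4 (0.54 log units; beyond the scatter), so a swap at this aromatic carbon that adds a six-membered aromatic ring of carbon only can weaken the compound. The 1-benzofuran-2-yl group does not set the level alone, since methyl in place of methoxy elsewhere on the shared core gives an at least 4.4-fold higher number from compound 1 to compound 4 (0.65 log units; beyond the scatter).

The step from compound 2 to compound 4 cannot be read, as both values are limits. Still open, as far as these compounds go, is how thiophen-2-yl behaves with methoxy in place of methyl, and what an amine or a longer chain would do at the place that holds those two groups.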